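The source may report more compounds than this note shows. Statements on the series, on what has been measured and on what is new or still open speak of the compounds shown alone.

Measured so far in a functional assay on UACC-62 cells (Homo sapiens) for cytotoxicity, read by sulforhodamine B assay, with a stated time of 48 h; on this read-out higher numbers stand for weaker inhibition of growth and lower numbers for stronger inhibition of growth:
- compound 1 `ClCc1ccc(Cn2cnc3c(Cl)ncnc32)cc1`: 33900 nM
- compound 2 `ClCc1cccc(Cn2cnc3ncnc(Cl)c32)c1`: 5370 nM

Of the two numbers in hand, compound 2 holds the lower one; compound 1 stands higher by a margin beyond the usual scatter, so on this read-out compound 2 is the more growth-inhibitory of the pair. For the measured compounds named here, the two structures differ in more than one place, so no single step between them is counted; only their two values are compared here.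

Compound 3 `ClCc1cccc(Cn2cnc3nc(Cl)nc(Cl)c32)c1` has not yet been run in this assay. It departs from compound 2 by chloro in place of hydrogen on an aromatic carbon, that is, a second chloro entering the shared core. No measured pair covers a change of this kind in the series, so the direction is open. The expectation is a step of no more than modest size, a 1.3-fold lower number from compound 2 to compound 3 (0.13 log units; within the scatter), with no firm reason to place it beyond the scatter. Compound 3 is accordingly estimated at 4000 nM, within a range of 1300 nM to 12000 nM.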

Compound 3, concentration for total growth inhibition: 2180 nM
The estimate for compound 3 lay 1.8-fold (0.26 log units) above the measured number, and the stated range covers the measured number.
By their numbers in this assay, from the lowest: compound 3; then compound 2; then compound 1.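

In this assay, for the compounds shown here, chloro in place of hydrogen on the aromatic carbon between two ring nitrogen atoms gives a 2.5-fold lower number from compound 2 to compound 3 (0.39 log units; beyond the scatter) and is the first single-place step. This position of the shared core therefore tolerates a second chloro, and growth inhibition grows stronger rather than being lost, though the step is modest and rests on this one pair. Nothing at hand bears on why the number falls.

On these data alone, whether this step is particular to chloro stays open: an amine, a methoxy group or a methyl group on the same carbon would test that. Also open, as far as these compounds go, is whether the second chloro would move the number in the same direction on the core of compound 1.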